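Amino in place of fluoro on compound 3

A few compounds are considered here, and "the series" means these few. Any claim that something is new, unique, unknown or untested is made for them only; others in the source may bear on it.

Compound 3 `COc1ccc(C(=O)c2cc(OC)c(OC)c(OC)c2)cc1NC(=O)/C=C/c1ccc(F)cc1` gives 400 nM in a functional assay on B16 cells (Mus musculus) for cytotoxicity, read by MTT assay, with a stated time of 72 h (on this read-out lower numbers stand for stronger inhibition and higher numbers for weaker inhibition), the second highest of the three numbers measured. Compound 1 `COc1ccc(C(=O)c2cc(OC)c(OC)c(OC)c2)cc1N` gives 30 nM and compound 2 `COc1ccc(C(=O)c2cc(OC)c(OC)c(OC)c2)cc1NC(=O)/C=C/c1ccc(OC)c(OC)c1` gives 6300 nM. Compound 4 `COc1ccc(C(=O)c2cc(OC)c(OC)c(OC)c2)cc1NC(=O)/C=C/c1ccc(N)cc1` differs from compound 3 by amino in place of fluoro on an aromatic carbon. Among the measured compounds shown here, two measured steps bear on this change: a 13-fold higher number from compound 1 to compound 3 (1.12 log units; beyond the scatter) and a 16-fold lower number from compound 2 to compound 3 (1.20 log units; beyond the scatter). For the measured compounds named here, the second shows that what sits on that ring can move the number strongly, yet no measured compound carries an amino there, so the direction stays uncertain. A modest rise is therefore expected, a 2.0-fold higher number from compound 3 to compound 4 (0.30 log units; within the scatter). Compound 4 is estimated at 800 nM, with a range from 200 nM to 4000 nM.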

Compound 4, half-maximal inhibitory concentration: 7900 nM
Compound 4: the middle estimate sits 9.9-fold (0.99 log units) below what was measured; measured number above the stated range.
By their numbers in this assay, from the lowest: compound 1; then compound 3; then compounds 2 and 4 (each within the scatter of the next).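

On this aromatic carbon, a change as small as amino in place of fluoro gives a 20-fold higher number from compound 3 to compound 4 (1.30 log units; beyond the scatter), so this position is sensitive even to a swap of one heavy atom. The 4-aminophenyl and 3,4-dimethoxyphenyl ends cannot be told apart, with a 1.3-fold higher number from compound 2 to compound 4 (0.10 log units; within the scatter), although the two groups differ in what they carry. Adding the whole (2-(4-aminophenyl)ethenyl)carbonyl to the nitrogen gives a 260-fold higher number from compound 1 to compound 4 (2.42 log units; beyond the scatter), so here the added chain does not preserve the low number of the parent amine. Nothing shown explains the effect of amino at this position. On these data alone, whether a hydroxyl or a dimethylamino group here would sit near fluoro or near amino stays open.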